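Ester Chain Length and Tolerance in Two Catechols

This account rests on a few compounds, and the source may have more. Where it says the series, first, only, none or still open, it means among the compounds named here.

compound 1 `CCCCOC(=O)CCc1ccc(O)c(O)c1` — 200 ug/mL
compound 2 `CC(=O)OCCc1ccc(O)c(O)c1` — 50 ug/mL

In an ADME assay on HEp-2 cells (Homo sapiens) for cytotoxicity, read by MTT assay, with a stated time of 24 h (a higher number here means that more compound is tolerated, a lower number that less compound is tolerated), compound 1 gives 200 ug/mL. Compound 2 gives 50 ug/mL in this assay, the lowest of the two numbers in hand; compound 1 stands at the higher number, and the gap between them lies beyond the usual scatter. Compound 3 `CCC(=O)OCCc1ccc(O)c(O)c1` has not yet been measured in this assay. It differs from compound 2 by methyl in place of hydrogen on a saturated chain carbon bound to a carbonyl carbon. Among the compounds with values here, no measured pair shares this change, so nothing beyond the two values above bears on it. The step of a 1.3-fold higher number from compound 2 to compound 3 (0.11 log units; within the scatter) is expected to be small, leaning toward a higher number if anything, and could fall within the scatter. Compound 3 is accordingly estimated at 65 ug/mL, with a range from 30 ug/mL to 140 ug/mL.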

Compound 3, half-maximal cytotoxic concentration: 40 ug/mL
For compound 3 the middle estimate is 1.6-fold (0.21 log units) above the measured one, and the stated range covers the measured number.
By their numbers in this assay, from the lowest: compounds 3 and 2 (each within the scatter of the next); then compound 1.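

In this assay, methyl in place of hydrogen on a saturated chain carbon bound to a carbonyl carbon gives a 1.3-fold lower number from compound 2 to compound 3 (0.10 log units; within the scatter), the first step read at this position. Going from acetyl to propanoyl therefore leaves the tolerated concentration indistinguishable at this place, so this one-carbon extension has no effect that this assay can resolve. The data in hand offer no explanation for this result.

From the compounds shown here alone, whether a longer chain such as butanoyl, or an amine or a carboxylic acid on this same carbon, would also stay within the scatter of compound 2 remains open. The steps from compound 1 to the other two compounds cannot be read, as it differs from each in more than one place, so its number says nothing about this position.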